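The source may hold more compounds than are shown below. What is called first, only, known or untested is meant among the compounds shown, and "the series" means these compounds.

Measured so far in a functional assay on DLD-1 cells (Homo sapiens) for inhibition, read by luminescence, with a stated time of 3 days (a higher number here means a weaker inhibitor of growth, a lower number a stronger inhibitor of growth), for this series:
- compound 1 (`CC(C)C1=C(C(=O)N2[C@H](C)CC[C@H]2C(=O)N2CCN(C)CC2)SC2=N[C@@](C)(c3ccc(Cl)cc3)[C@@H](c3ccc(Cl)cc3)N21`) gives 9000 nM
- compound 2 (`CC(=O)N1CCN(C(=O)[C@@H]2CC[C@@H](C)N2C(=O)C2=C(C(C)C)N3C(=N[C@@](C)(c4ccc(Cl)cc4)[C@H]3c3ccc(Cl)cc3)S2)CC1`) gives 16000 nM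
- compound 3 (`CC[C@@H]1CC[C@@H](C(=O)N2CCOCC2)N1C(=O)C1=C(C(C)C)N2C(=N[C@@](C)(c3ccc(Cl)cc3)[C@H]2c2ccc(Cl)cc2)S1`) gives 4200 nM

Compound 3 has the lowest of the three numbers, and its gaps to compound 1 and compound 2 both lie beyond the scatter. Compound 4 (`CC[C@@H]1CC[C@@H](C(=O)N2CCN(C(C)=O)[C@@H](C)C2)N1C(=O)C1=C(C(C)C)N2C(=N[C@@](C)(c3ccc(Cl)cc3)[C@H]2c2ccc(Cl)cc2)S1`) differs from compound 3 by one change: a group of 10 heavy atoms (7 carbon, 2 nitrogen, 1 oxygen; one six-membered non-aromatic ring with 2 hetero atoms) in place of a group of 6 heavy atoms (4 carbon, 1 nitrogen, 1 oxygen; one six-membered non-aromatic ring with 2 hetero atoms), on a carbonyl carbon and nothing else. Among the compounds with values here, no measured step replaces morpholin-4-yl directly. The nearest evidence is the acetyl in place of methyl on a ring nitrogen, which compound 4 also carries as acetyl, and there the measured step is a 1.8-fold higher number from compound 1 to compound 2 (0.25 log units; within the scatter) and stays within the scatter. Compound 2 also shows that an acetylated ring can still give a measurable 16000 nM in this assay without loss of a number. On that single small step, no change beyond the scatter is expected, with any drift expected towards a higher number. The estimated step is a 1.4-fold higher number from compound 3 to compound 4 (0.15 log units; within the scatter) and remains tentative. For compound 4 the estimate is 6000 nM with an expected range from 2500 nM to 15000 nM in all.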

Compound 4, concentration for 50% growth inhibition: 2600 nM
Compound 4: middle estimate off by 2.3-fold (0.36 log units), on the high side; measured number inside the range.
By their numbers in this assay, from the lowest: compounds 4 and 3 (each within the scatter of the next); then compounds 1 and 2 (each within the scatter of the next).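

In this assay, the group of 10 heavy atoms in place of morpholin-4-yl on the carbonyl carbon gives a 1.6-fold lower number from compound 3 to compound 4 (0.21 log units; within the scatter), so this large exchange of the group on the carbonyl carbon leaves the number within the scatter. The earlier step altered only the substituent on a ring nitrogen, whereas this one replaces morpholin-4-yl itself and adds a defined stereocentre. No measurement bears on why the number stays within the scatter.

The ring methyl and the acetyl enter together, so the contribution of each to this step remains unresolved. Going by these compounds, it also remains open how this assay responds at this carbonyl carbon to a group of another kind, such as a free amine, a carboxylic acid or an open dialkylamino chain.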